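This account rests on a few compounds, and the source may have more. Where it says the series, first, only, none or still open, it means among the compounds named here.

Working notes on the series. Compound 1 `O[C@H](c1ccccn1)[C@]1(c2ccc(C(F)(F)F)cc2)C[C@@H](O)C1` gives 50 mL/min/kg in an ADME assay on liver for metabolic stability, with Liver microsome (Rattus norvegicus) as the target, read by LC-MS, using microsomes, with a stated time of 5 h; a lower number here means slower removal, a higher number faster removal of the compound. Compound 2 `OC(c1ccccn1)C1(c2ccc(Cl)c(Cl)c2)CCOC1` gives 983 mL/min/kg in this assay. Compound 3 `C[C@@]1(c2ccc(OC(F)(F)F)cc2)C[C@@](O)(c2ccccn2)CO1` gives 333 mL/min/kg in this assay, the second highest of the three numbers: compound 2 sits higher by a gap beyond the scatter, and compound 1 sits lower by a wider gap, also beyond the scatter. Among the compounds with values here, compound 4 `C[C@]1(c2ccc(OC(F)(F)F)cc2)C[C@@](O)(c2ccccn2)CO1` is not yet measured. the two compounds have the same atoms and bonds and differ only in configuration as drawn: 1 of 2 stereo elements differ; a stereocentre at a saturated ring carbon is drawn S in compound 3 and R in compound 4 No measured pair in this set shows a change of this kind, so no direction can be drawn from the data; the expected outcome is a step within the scatter, in either direction, amounting to a 1.1-fold lower number from compound 3 to compound 4 (0.05 log units; within the scatter). For compound 4 the estimated clearance in this assay is 300 mL/min/kg, with a range from 150 mL/min/kg to 600 mL/min/kg.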

Compound 4, clearance: 150 mL/min/kg
Compound 4: middle estimate off by 2.0-fold (0.30 log units), on the high side; measured number inside the range.
By their numbers in this assay, from the lowest: compound 1; then compound 4; then compound 3; then compound 2.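

The series now holds its first one-place step in this assay, with a 2.2-fold lower number from compound 3 to compound 4 (0.35 log units; beyond the scatter). Configuration at this saturated ring carbon therefore registers in the clearance read-out, with the R form as drawn giving the lower number of the pair. The step can be assigned to this stereocentre alone because nothing else separates the pair: the fact that compounds 3 and 4 differ only in the configuration as drawn

Going by these compounds, whether the second stereo element, shared by both compounds, has a comparable influence remains open. Also open, on these data alone, is whether the step persists when the hydroxyl on this core gives way to an amine or a carboxylic acid.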